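Swapping oxan-4-yl for 4,4-dimethylcyclohexyl on an amine

The source may report more compounds than this note shows. Statements on the series, on what has been measured and on what is new or still open speak of the compounds shown alone.

Measured compounds in a functional assay on cells for agonist activity at C-X-C chemokine receptor type 4 (Homo sapiens), read by fluorescence and calcium flux, with a stated time of 90 s; on this read-out higher numbers stand for an effect only at larger amounts of compound and lower numbers for an effect already at smaller amounts:
Compound 1 `c1ccc2c(c1)CN[C@@H](CN(Cc1ccc(CNC3CCOCC3)cc1)[C@H]1CCCc3cccnc31)C2` gives > 30000 nM, which is a limit of the assay and not a number.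
Compound 2 `CC1(C)CCC(NCc2ccc(CN(C[C@H]3Cc4ccccc4CN3)[C@H]3CCCc4cccnc43)cc2)CC1` gives > 30000 nM, also a limit of the assay.
Compound 3 `CC(C)(CCN(C[C@H]1Cc2ccccc2CN1)[C@H]1CCCc2cccnc21)CNC1CCOCC1` gives > 30000 nM, again a limit of the assay.

From compound 1 to compound 2 the change is 4,4-dimethylcyclohexyl in place of oxan-4-yl on an amine nitrogen, and the step that the two limits leave unreadable from compound 1 to compound 2 cannot be sized because of the limit of > 30000 nM in this assay, at which 3 of the 3 values shown sit.

Compound 4 `CC1(C)CCC(NCC(C)(C)CCN(C[C@H]2Cc3ccccc3CN2)[C@H]2CCCc3cccnc32)CC1` is not yet measured. It carries the same change as compound 3 does from compound 1: 4,4-dimethylcyclohexyl in place of oxan-4-yl on an amine nitrogen. The difference between the core of compound 3 and the core of compound 1 is not broken down here.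

Compound 3 sits at the limit, and compound 1 and compound 2 both sit there too, so compound 4 is expected to stay at the limit as well, with an estimated step of a number no higher from compound 3 to compound 4 (the limit leaves the size open). The estimate for compound 4 is 30000 nM, spanning 10000 nM to 100000 nM.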

Compound 4, half-maximal effective concentration: > 30000 nM
Compound 4 ended at the assay's limit (the forecaster's own chance of this, stated with the estimate: 85%); the middle value sits exactly at the limit.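

No step can be read from compound 3 to compound 4 in this assay, and the reason is a shared limit: the limit of > 30000 nM in this assay, at which 4 of the 4 values shown sit.

The compounds shown leave open whether swapping oxan-4-yl for 4,4-dimethylcyclohexyl changes the effect at all, since none of them gives a measurable value.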